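Lengthening an unsaturated ester side chain on a shared core

This account rests on a few compounds, and the source may have more. Where it says the series, first, only, none or still open, it means among the compounds named here.

Compound 1 `C=C[C@]1(C)C[C@H](OC(=O)[C@@H](C)CO)[C@@H]2[C@H](OC(=O)[C@H]2CN2CCC[C@H]2C(=O)O)[C@H]1C(=C)CO`: > 50000 nM
Compound 2 `C=C[C@]1(C)C[C@H](OC(=O)C(=C)CO)[C@@H]2[C@H](OC(=O)[C@H]2CN2CCC[C@H]2C(=O)O)[C@H]1C(=C)CO`: > 50000 nM

Both measurements come from an assay on isolated protein for inhibition of Tyrosinase (Homo sapiens); on this read-out higher numbers stand for weaker inhibition and lower numbers for stronger inhibition. Compound 1 gives > 50000 nM, which is a limit of this assay rather than a number. Compound 2 likewise gives > 50000 nM, again a limit and not a number. Among the measured compounds shown here, the single measured step, a step that the two limits leave unreadable from compound 1 to compound 2, therefore carries no readable size, because of the limit of > 50000 nM in this assay, at which 2 of the 2 values shown sit. Compound 2 thus stands at the limit, and nothing in the measured pair separates it from compound 1.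

Compound 3 `C=C[C@]1(C)C[C@H](OC(=O)/C(=C/C)CO)[C@@H]2[C@H](OC(=O)[C@H]2CN2CCC[C@H]2C(=O)O)[C@H]1C(=C)CO` differs from compound 2 by 1-(hydroxymethyl)prop-1-en-1-yl in place of 1-(hydroxymethyl)ethenyl on a carbonyl carbon. For the measured compounds named here, no measured step bears on this change in a readable way; the only step available is the unreadable one from the measured pair. Since both measured compounds sit at the limit, compound 3 is expected to sit there as well, with the estimated step that the limit leaves unreadable from compound 2 to compound 3 meaning no readable change. Compound 3 is therefore estimated at 100000 nM, with a range from 30000 nM to 1000000 nM, most likely reported only as a limit.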

Compound 3, half-maximal inhibitory concentration: > 50000 nM
Compound 3: a limit, no number (the forecaster's own chance of this, stated with the estimate: 90%); the middle value does not contradict the limit.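

Among the compounds shown here, no step among compound 1, compound 2 and compound 3 can be read, because each value is a limit and not a number: the limit of > 50000 nM in this assay, at which 3 of the 3 values shown sit.

The compounds shown leave open whether these three ester side chains differ at all in how strongly they inhibit the enzyme.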